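The compounds below may be only part of what the source reports. "The series", "measured", "known", "first", "only" and "open" are said of these compounds alone.

Of the compounds shown here, three sharing one core have been measured in a functional assay on PC-3 cells (Homo sapiens) for cytotoxicity, read by MTT assay, with a stated time of 72 h; a higher number here means a weaker inhibitor, a lower number a stronger inhibitor. Compound 1 `CCCOCNc1n[n+]([O-])c2cc(OC)ccc2[n+]1[O-]` gives 10600 nM there. Compound 2 `COc1ccc2c(c1)[n+]([O-])nc(NCOC(C)c1ccccc1)[n+]2[O-]` gives only a limit of this assay, > 100000 nM. Compound 3 `CCCCCOCNc1n[n+]([O-])c2ccccc2[n+]1[O-]` gives 8510 nM, the lowest of the two plain numbers, with compound 1 as its nearest neighbour at a distance that lies within the usual scatter.

Among the compounds with values here, the only measured step, an at least 9.4-fold higher number from compound 1 to compound 2 (0.97 log units; beyond the scatter), swaps the group on the oxygen of the side chain and leaves the aromatic ring untouched. Compound 4 `CCCCCOCNc1n[n+]([O-])c2cc(OC)ccc2[n+]1[O-]` differs from compound 3 in one place: methoxy in place of hydrogen on an aromatic carbon. Compound 1 and compound 3 differ both in this methoxy and in the length of the chain, and their values sit within the scatter of each other; apart from that, nothing measured here speaks to adding a methoxy to the ring. The expected step is therefore a 1.0-fold lower number from compound 3 to compound 4 (0.00 log units; within the scatter), a change that is not expected to reach beyond the scatter. Compound 4 is estimated at 8500 nM, with a range from 3000 nM to 25000 nM.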

Compound 4, half-maximal inhibitory concentration: 30900 nM
Estimate against measurement, compound 4: 3.6-fold (0.56 log units) below; measured number above the stated range.
By their numbers in this assay, from the lowest: compounds 3 and 1 (each within the scatter of the next); then compound 4. At a limit, above all of these: compound 2.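

In this assay, within the data shown here, this position on the ring responds to the change: methoxy in place of hydrogen gives a 3.6-fold higher number from compound 3 to compound 4 (0.56 log units; beyond the scatter), which the earlier compounds could not show, since compound 1 and compound 3 differ in two places at once. With the methoxy present, the side chain also matters, with a 2.9-fold higher number from compound 1 to compound 4 (0.46 log units; beyond the scatter) for ethyl in place of hydrogen on the chain, and an at least 3.2-fold lower number from compound 2 to compound 4 (0.51 log units; beyond the scatter) for pentyl in place of 1-phenylethyl. The value of compound 2 is a limit, not a plain number: the limit of > 100000 nM in this assay, at which 1 of the 4 values shown sits.

Going by these compounds, it remains open whether a fluorine or an amine on the same aromatic carbon would shift the number as methoxy does. Also open, on these data alone, is whether a butyl chain on the oxygen would fall between propyl and pentyl, and whether the chain step holds without the methoxy.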